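Notes on aryl variation within one amide series

This account rests on a few compounds, and the source may have more. Where it says the series, first, only, none or still open, it means among the compounds named here.

compound 1 `Cc1nc(-c2ccccc2)c(C(=O)N2CCN(c3ccc(Cl)c(Cl)c3)CC2)o1` — 124 nM
compound 2 `Cc1nc(-c2ccccc2)c(C(=O)N2CCN(c3cccc(Cl)c3Cl)CC2)o1` — 133 nM
compound 3 `Cc1nc(-c2ccccc2)c(C(=O)N2CCN(c3ccccc3Cl)CC2)o1` — 124 nM

In a functional assay on HL-60 cells (Homo sapiens) for inhibition, read by MTT assay, with a stated time of 72 h (a higher number here means a weaker inhibitor, a lower number a stronger inhibitor), compound 1 gives 124 nM, compound 2 gives 133 nM and compound 3 gives 124 nM. Among the measured compounds shown here, compound 3 stands level with compound 1, the two sharing the lowest numbers, and the one other step that ends at it is only a 1.1-fold lower number from compound 2 to compound 3 (0.03 log units; within the scatter). The remaining steps, a 1.1-fold higher number from compound 1 to compound 2 (0.03 log units; within the scatter) and no change at the digits printed from compound 1 to compound 3 (within the scatter), likewise stay within the scatter. Compound 4 `Cc1nc(-c2ccccc2)c(C(=O)N2CCN(c3cccc(C)c3C)CC2)o1` carries 2,3-dimethylphenyl in place of 2-chlorophenyl on an amine nitrogen in a ring. For the measured compounds named here, the three steps above bear on this change, since each varies the same aryl group without moving the number beyond the scatter; no measured step exchanges chloro for methyl. The expected step of a 1.0-fold higher number from compound 3 to compound 4 (0.02 log units; within the scatter) is therefore none beyond the scatter. Compound 4 is estimated at 130 nM, within 65 nM to 260 nM.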

Compound 4, half-maximal inhibitory concentration: 35 nM
Compound 4: middle estimate off by 3.7-fold (0.57 log units), on the high side; measured number outside the range, below it.
By their numbers in this assay, from the lowest: compound 4; then compounds 1, 3 and 2 (each within the scatter of the next).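

In this assay this aryl group on an amine nitrogen in a ring can move the number beyond the scatter, which the chlorinated compounds did not show: a 3.5-fold lower number from compound 3 to compound 4 (0.55 log units; beyond the scatter) and a 3.5-fold lower number from compound 1 to compound 4 (0.55 log units; beyond the scatter). The closest comparison is a 3.8-fold lower number from compound 2 to compound 4 (0.58 log units; beyond the scatter), where methyl groups stand in place of the chloro groups of the 2,3-dichlorophenyl group. Nothing available accounts for this shift. Still open, on these data alone, is whether one methyl group alone keeps the lower number, and whether an ethyl or methoxy group does the same.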